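The source may hold more compounds than are shown below. What is called first, only, known or untested is meant among the compounds shown, and "the series" means these compounds.

Measured compounds in the series:

- compound 1, `Cn1c(-c2ccc(NC(=O)CN3CCN(Cc4ccccc4)CC3)cc2)nc(-c2ccccc2)c1-c1ccccc1`: 26.8%
- compound 2, `COc1ccc(CN2CCN(CC(=O)Nc3ccc(-c4nc(-c5ccccc5)c(-c5ccccc5)n4C)cc3)CC2)cc1`: 17.8%

Both numbers come from a functional assay on HT-29 cells (Homo sapiens) for cytotoxicity, read by MTT assay, with a stated time of 24 h, tested at 6.4 ug/mL; on this read-out lower numbers stand for a weaker effect and higher numbers for a stronger effect at the one concentration tested. Among the compounds with values here, compound 2 stands at the lower of the two figures, but the gap to compound 1 is within the scatter, so the two compounds cannot be ordered on these data; the single measured step, a number 9 percentage points lower from compound 1 to compound 2 (within the scatter), shows the same thing.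

The next compound, compound 3, `Cn1c(-c2ccc(NC(=O)CN3CCN(Cc4ccc(Cl)cc4)CC3)cc2)nc(-c2ccccc2)c1-c1ccccc1`, differs from compound 2 by chloro in place of methoxy on an aromatic carbon. Within the data shown here, no measured step involves a chloro group, and the only step available, from hydrogen to methoxy, lies within the scatter. There is therefore no basis for expecting a move beyond the scatter in either direction in this assay; the expectation for compound 3 is a number close to that of compound 2, with the spread widened to cover the lack of a direct precedent.

The expected step is a number 4.2 percentage points higher from compound 2 to compound 3 (within the scatter). For compound 3 the estimate in this assay is 22%, with a range from 8% to 38%.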

Compound 3, a percentage reported as activity, at one concentration (the size of the read-out at that concentration, not a potency): 41.5%
Estimate against measurement, compound 3: 19.5 percentage points below, outside the stated range (above it).
By their numbers in this assay, from the lowest: compounds 2 and 1 (each within the scatter of the next); then compound 3.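

In this assay, the aromatic carbon para to a large group now proves responsive to substitution: chloro in place of methoxy gives a number 23.7 percentage points higher from compound 2 to compound 3 (beyond the scatter), and chloro in place of hydrogen gives a number 14.7 percentage points higher from compound 1 to compound 3 (beyond the scatter). The earlier change from hydrogen to methoxy at this carbon stayed within the scatter, so the two earlier compounds could not show whether the group here mattered; the 4-chlorobenzyl compound now sets itself apart from both the unsubstituted benzyl and the 4-methoxybenzyl compounds, although both steps remain modest. Nothing available explains why chloro differs from methoxy and hydrogen at this carbon.

A single chloro example leaves open whether the rise belongs to chloro alone or would also appear with fluoro, bromo, trifluoromethyl or an amine at the same carbon. On these data alone, the figures also describe the size of the effect at one concentration, so whether compound 3 would hold its place across a range of concentrations remains open.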